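Cyanomethyl pyrazole series: dimethylamino for phenoxy at the aryl

A few compounds are considered here, and "the series" means these few. Any claim that something is new, unique, unknown or untested is made for them only; others in the source may bear on it.

Two compounds of the series carry readings in a functional assay on UO-31 cells (Homo sapiens) for cytotoxicity, read by sulforhodamine B assay, with a stated time of 48 h, tested at 0.01 uM; a higher number here means a weaker effect of the compound at the concentration tested, a lower number a stronger effect. Compound 1 `COc1cc(C)cc(-c2c(-c3ccnc(-c4ccc(C(C)=O)cc4)c3)cnn2CC#N)c1` gives 87% in this assay. Compound 2 `Cc1cc(O)cc(-c2nn(CC#N)cc2-c2ccnc(-c3ccc(Oc4ccccc4)cc3)c2)c1` gives 85% in this assay. The two readings lie within the scatter of each other, so the numbers shown so far do not separate compound 2 from compound 1; at the concentration tested both leave most of the cells growing.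

The next compound, compound 3 `Cc1cc(O)cc(-c2nn(CC#N)cc2-c2ccnc(-c3ccc(N(C)C)cc3)c2)c1`, is not yet measured in this assay. It differs from compound 2 in one place: dimethylamino in place of phenoxy on an aromatic carbon. The shared core, the nitrile-bearing chain and the methyl- and hydroxy-substituted aryl are kept; only the group at the far aryl is exchanged.

Going by the values given here, no step between measured compounds is available, so the size of the effect of this exchange cannot be read from the series. Given that compound 2 shows 85%, the step of a number 1 percentage points higher from compound 2 to compound 3 (within the scatter) is expected to stay within the scatter. For compound 3 the estimate in this assay is 86%, with a likely range from 72% to 100%.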

Compound 3, a percentage reported as activity, at one concentration (the size of the read-out at that concentration, not a potency): 84%
Beside the measured number, compound 3's estimate is 2 percentage points above it; measured number inside the range.
By their numbers in this assay, from the lowest: compounds 3, 2 and 1 (each within the scatter of the next).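

In this assay, going by these compounds alone, replacing phenoxy with dimethylamino gives a number 1 percentage points lower from compound 2 to compound 3 (within the scatter), the only step so far that isolates one place, an aromatic carbon para to a large group. The exchange removes a six-membered aromatic ring and reduces the group from 7 heavy atoms to 3, with oxygen giving way to nitrogen as the attached atom, yet the reading does not separate the two compounds at this single concentration, so this one pair gives no sign that the ring is needed for the read-out. No measurement available here bears on why the two groups read alike.

From the compounds shown here alone, whether a carboxylic acid, a primary amine or a longer chain such as diethylamino at this carbon would give a step beyond the scatter remains open. A reading at one low concentration is also not a potency, so any difference between phenoxy and dimethylamino at higher concentrations in this assay remains unresolved.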